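Trading the benzyl ring of compound 3 for an isopentyl chain

The compounds below may be only part of what the source reports. "The series", "measured", "known", "first", "only" and "open" are said of these compounds alone.

Of the compounds shown here, three with a shared spirocyclic core have been measured in an assay for displacement of a labelled ligand from Sigma non-opioid intracellular receptor 1 (Cavia porcellus), read by scintillation counting, with a stated time of 180 min; on this read-out lower numbers stand for stronger inhibition and higher numbers for weaker inhibition. Compound 1 `COC1Cc2c(cnn2C)C2(CCN(Cc3ccc(F)cc3)CC2)O1` gives 21 nM. Among the compounds with values here, compound 2 `COC1Cc2c(cnn2C)C2(CCN(CCCc3ccccc3)CC2)O1` gives 93 nM, and the only single-point step among the measured compounds, a 4.4-fold higher number from compound 1 to compound 2 (0.65 log units; beyond the scatter), shows that lengthening the arylalkyl arm on the ring nitrogen costs affinity. Compound 3 `c1ccc(CN2CCC3(CC2)OCCc2c3cnn2-c2ccccc2)cc1` gives 1.71 nM, the lowest of the three numbers; its gap to compound 1 and to compound 2 lies beyond the scatter in each case, so it is the most potent of the measured set.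

Compound 4 `CC(C)CCN1CCC2(CC1)OCCc1c2cnn1-c1ccccc1` differs from compound 3 by isobutyl in place of phenyl on a saturated chain carbon bound to an amine nitrogen in a ring, so that the whole aromatic ring of the benzyl arm is gone and a branched alkyl chain of similar length stands in its place. Within the data shown here, no measured step removes an aromatic ring in this way; the nearest comparison is the change from compound 1 to compound 2, where altering the arm on the same nitrogen already gave a modest loss. A step of comparable or somewhat larger size, towards a higher number, is therefore expected: a 4.7-fold higher number from compound 3 to compound 4 (0.67 log units; beyond the scatter). Compound 4 is accordingly estimated at 8 nM in this assay, with a range from 2 nM to 40 nM.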

Compound 4, inhibition constant: 0.98 nM
Compound 4: middle estimate off by 8.2-fold (0.91 log units), on the high side; the measured number lies below the stated range.
By their numbers in this assay, from the lowest: compounds 4 and 3 (each within the scatter of the next); then compound 1; then compound 2.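

In this assay the exchange of phenyl for isobutyl on a saturated chain carbon bound to an amine nitrogen in a ring gives a 1.7-fold lower number from compound 3 to compound 4 (0.24 log units; within the scatter), so on the core of compound 3 this arm keeps its low number without the aromatic ring of the benzyl group. The earlier change on the ring nitrogen, on the core of compound 1, gave a 4.4-fold higher number from compound 1 to compound 2 (0.65 log units; beyond the scatter), which lay beyond the scatter; a change of arm at this nitrogen therefore does not always carry a cost, although the two steps involve different arms on different cores. No separate evidence bears on this result, and what lies behind it stays unexplained.

The compounds shown leave open whether the same exchange would hold on the core of compound 1, where an isopentyl arm would make the direct comparison. They also leave open whether a cyclohexylmethyl group, an unbranched longer chain or an amine on the chain would stay as close to compound 3 as the isopentyl arm does.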